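The compounds below may be only part of what the source reports. "The series", "measured", "known", "first", "only" and "open" are said of these compounds alone.

Measured so far:
compound 1 `C/N=C(\NC#N)NCCCCn1nc(-c2ccccc2)ccc1=O` — 38.5 mg/kg
compound 2 `NC(=O)SCCCCCN1NC=CC=C1c1ccccc1` — 18.3 mg/kg

Of the compounds shown here, two have been measured in a functional assay on the whole organism with Rattus norvegicus as the target; on this read-out higher numbers stand for an effect only at larger amounts of compound and lower numbers for an effect already at smaller amounts. Compound 1 `C/N=C(\NC#N)NCCCCn1nc(-c2ccccc2)ccc1=O` gives 38.5 mg/kg in this assay, the higher of the two numbers; compound 2 `NC(=O)SCCCCCN1NC=CC=C1c1ccccc1` gives 18.3 mg/kg, and the gap between these two values lies beyond the scatter. Compound 2 differs from compound 1 in more than one place, so the two values alone tell how far apart they lie.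

The next compound, compound 3 `CC/N=C(\S)NCCCCn1nc(-c2ccccc2)ccc1=O`, is derived from compound 1 by one change: a group of 5 heavy atoms (3 carbon, 1 nitrogen, 1 sulfur; no ring) in place of a group of 6 heavy atoms (3 carbon, 3 nitrogen; no ring), on an amine nitrogen. Among the measured compounds shown here, no measured pair shows this particular change, so its effect in this assay is open. The group that enters is smaller by one heavy atom and carries one fewer acceptor than the group that leaves; compound 2, which also carries sulfur in its chain terminus, sits lower than compound 1, but it is not a single-change comparison. The expected step from compound 1 to compound 3 is a 1.4-fold lower number from compound 1 to compound 3 (0.14 log units; within the scatter), a modest move toward lower numbers that may stay within the scatter. Compound 3 is therefore estimated at 28 mg/kg, within a range from 11 mg/kg to 70 mg/kg.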

Compound 3, dose for half-maximal effect: 19.8 mg/kg
For compound 3 the middle estimate is 1.4-fold (0.15 log units) above the measured one, within the range that was stated.
By their numbers in this assay, from the lowest: compounds 2, 3 and 1 (each within the scatter of the next, the first and the last beyond it).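

In this assay, among the compounds shown here, the change on the amine nitrogen can now be read on its own for the first time, as a 1.9-fold lower number from compound 1 to compound 3 (0.29 log units; within the scatter). The group of 5 heavy atoms (3 carbon, 1 nitrogen, 1 sulfur; no ring) can therefore take the place of the group of 6 heavy atoms (3 carbon, 3 nitrogen; no ring) on the core of compound 1 with a step that stays within the scatter, so the triple bond of the group that leaves is not needed for a number in this range. No measurement shown here accounts for this step.

A single step gives no trend at this position. As far as these compounds go, whether a urea or a carboxylic acid on this nitrogen, or a longer chain in compound 3, would stay within the scatter of compound 3 remains open.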